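This account rests on a few compounds, and the source may have more. Where it says the series, first, only, none or still open, it means among the compounds named here.

Measured in an ADME assay on HepG2 2.2.15 cells (Homo sapiens) for cytotoxicity; a higher number here means that more compound is tolerated, a lower number that less compound is tolerated:
Compound 1, `CC(=O)OCCc1c(-c2ccccc2Cl)c2cc(Cl)ccc2[nH]c1=O`: 27000 nM
Compound 2, `CCCC(=O)OCCc1c(-c2ccccc2Cl)c2cc(Cl)ccc2[nH]c1=O`: 52000 nM
Compound 3, `CCCCCCCC(=O)OCCc1c(-c2ccccc2Cl)c2cc(Cl)ccc2[nH]c1=O`: 78000 nM

Compound 1 stands at the low end of these three numbers: the step of a 1.9-fold higher number from compound 1 to compound 2 (0.28 log units; within the scatter) is within the scatter, while a 2.9-fold higher number from compound 1 to compound 3 (0.46 log units; beyond the scatter) is a modest step beyond it. Compound 4, `CC(=O)N1CCC(C(=O)OCCc2c(-c3ccccc3Cl)c3cc(Cl)ccc3[nH]c2=O)CC1`, has not yet been measured in this assay. It differs from compound 1 in one place: 1-acetylpiperidin-4-yl in place of methyl on a carbonyl carbon. The steps from compound 1 to compound 2 and to compound 3 bear on this change, since both enlarge the group on the same carbonyl carbon, and both gave a higher number, only one of them beyond the scatter. A small rise in this assay is therefore expected, but the step of a 1.5-fold higher number from compound 1 to compound 4 (0.17 log units; within the scatter) is expected to lie near the scatter. Compound 4 is estimated to give 40000 nM, with a range from 18000 nM to 90000 nM.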

Compound 4, half-maximal cytotoxic concentration: 82000 nM
Beside the measured number, compound 4's estimate is 2.1-fold (0.31 log units) below it, within the range that was stated.
By their numbers in this assay, from the lowest: compounds 1, 2, 3 and 4 (each within the scatter of the next, the first and the last beyond it).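

In this assay, a ring on this carbonyl carbon behaves like the open chains: 1-acetylpiperidin-4-yl in place of methyl gives a 3.0-fold higher number from compound 1 to compound 4 (0.48 log units; beyond the scatter), with its one hydrogen-bond acceptor and hetero atom bringing no fall in the number. The ring group also stays within the scatter of both longer chains, with a 1.6-fold higher number from compound 2 to compound 4 (0.20 log units; within the scatter) and a 1.1-fold higher number from compound 3 to compound 4 (0.02 log units; within the scatter), so these three compounds cannot be ordered. No measurement here accounts for the rise from compound 1.

From the compounds shown here alone, it remains open how an amine or a carboxylic acid on this carbonyl carbon would read in this assay.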